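The source may report more compounds than this note shows. Statements on the series, on what has been measured and on what is new or still open speak of the compounds shown alone.

Values so far in a functional assay on WM1361 cells (Homo sapiens) for antiproliferative activity, read by MTT assay, with a stated time of 48 h; on this read-out lower numbers stand for stronger inhibition and higher numbers for weaker inhibition
compound 1 `O=C(Nc1cc(-c2ccccc2)[nH]n1)c1ccc(Br)nc1` gives 19400 nM
compound 2 `Cc1ccc(-c2cc(NC(=O)c3cccnc3Cl)n[nH]2)cc1` gives 15800 nM
compound 3 `COc1ncccc1C(=O)Nc1cc(-c2ccc(C)cc2)[nH]n1` gives 25800 nM

Compound 2 stands within the scatter of both compound 1 and compound 3, so these values give no ranking. Compound 4 `Cc1ccc(-c2cc(NC(=O)c3ccc(Br)nc3)n[nH]2)cc1` carries 6-bromopyridin-3-yl in place of 2-chloropyridin-3-yl on a carbonyl carbon. Within the data shown here, the one measured step, methoxy in place of chloro on an aromatic carbon, stays small (a 1.6-fold higher number from compound 2 to compound 3 (0.21 log units; within the scatter)). Compound 1 carries the same 6-bromopyridin-3-yl group and gives (19400 nM) in the same read-out. No step beyond the scatter is therefore expected in this assay for this change. The expected step is small (a 1.1-fold higher number from compound 2 to compound 4 (0.06 log units; within the scatter)). For compound 4 the estimated value is 18000 nM with an expected range from 9000 nM as lower end to 35000 nM as upper end.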

Compound 4, half-maximal inhibitory concentration: 18600 nM
Compound 4: middle estimate off by 1.0-fold (0.01 log units), on the low side; the range from low to high includes it.
By their numbers in this assay, from the lowest: compounds 2, 4, 1 and 3 (each within the scatter of the next).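

In this assay, 6-bromopyridin-3-yl in place of 2-chloropyridin-3-yl on a carbonyl carbon stays inside the scatter (a 1.2-fold higher number from compound 2 to compound 4 (0.07 log units; within the scatter)), so a second change at this place, after the methoxy for chloro exchange, gives no ranking. Methyl in place of hydrogen on an aromatic carbon, a change at a second place, also stays inside the scatter (a 1.0-fold lower number from compound 1 to compound 4 (0.02 log units; within the scatter)). Nothing available explains either result.

Still open, going by these compounds, is whether any change at these places gives a step beyond the scatter. An amine or a carboxylic acid in place of the bromine, or a longer chain in place of the methyl, would test this.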